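Adding a second bromo to compound 2

The source may hold more compounds than are shown below. What is called first, only, known or untested is meant among the compounds shown, and "the series" means these compounds.

Compound 1 `COc1ccc(/C=N/NC(=O)Nc2ccc(Oc3ccnc4[nH]ccc34)c(F)c2)cc1` gives 5750 nM
Compound 2 `O=C(N/N=C/c1ccc(O)c(Br)c1)Nc1ccc(Oc2ccnc3[nH]ccc23)c(F)c1` gives 8230 nM

Both numbers come from a functional assay on MCF7 cells (Homo sapiens) for antiproliferative activity, read by MTT assay, with a stated time of 72 h (a lower number here means a stronger inhibitor, a higher number a weaker inhibitor), and lie within the scatter of each other, so compound 2 stands level with compound 1 on the data so far. Compound 3 (`O=C(N/N=C/c1cc(Br)c(O)c(Br)c1)Nc1ccc(Oc2ccnc3[nH]ccc23)c(F)c1`) has not yet been measured in this assay. Its difference from compound 2 is a bromo in place of hydrogen on an aromatic carbon, ortho to a hydroxy group, which turns 3-bromo-4-hydroxyphenyl into 3,5-dibromo-4-hydroxyphenyl.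

Within the data shown here, only one measured step bears on this (a 1.4-fold higher number from compound 1 to compound 2 (0.16 log units; within the scatter)). That step brought in a bromo together with other changes, and it stayed small. Among the measured compounds shown here, no measured pair shows a bromo change alone, so the basis is thin and the range must stay wide. No shift beyond the scatter is expected, in either direction (a 1.1-fold lower number from compound 2 to compound 3 (0.04 log units; within the scatter)). The estimated value for compound 3 is 7500 nM (expected range 3000 nM to 18000 nM).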

Compound 3, half-maximal inhibitory concentration: "not active" (no number reported)
No number was reported for compound 3; there is nothing to compare the estimate with.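

In this assay, among these compounds, compound 3 is reported as "not active" without a number, so no step from compound 2 to compound 3 can be read. The compounds shown leave open what size of change, if any, goes with 3,5-dibromo-4-hydroxyphenyl in place of 3-bromo-4-hydroxyphenyl. Nothing at hand accounts for this result.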